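A few compounds are considered here, and "the series" means these few. Any claim that something is new, unique, unknown or untested is made for them only; others in the source may bear on it.

Measured so far:
Compound 1 `Cc1ccc(NS(=O)(=O)c2ccc(-c3ccccc3)cc2)cc1Nc1nccc(-c2cccnc2)n1` — 11900 nM
Compound 2 `Cc1ccc(NS(=O)(=O)c2cnc3ccccc3c2)cc1Nc1nccc(-c2cccnc2)n1` — 9960 nM

In a functional assay on MCF7 cells (Homo sapiens) for cytotoxicity, read by MTT assay, with a stated time of 24 h (a higher number here means a weaker inhibitor, a lower number a stronger inhibitor), compound 1 gives 11900 nM. Compound 2 gives 9960 nM, so the two stand together: the step of a 1.2-fold lower number from compound 1 to compound 2 (0.08 log units; within the scatter) is within the scatter, and it concerns only the group on the sulfonyl sulfur, where quinolin-3-yl replaces 4-phenylphenyl.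

Compound 3 `COc1cc(-c2ccnc(Nc3cc(NS(=O)(=O)c4ccc(-c5ccccc5)cc4)ccc3C)n2)cc(OC)c1OC` differs from compound 1 elsewhere: 3,4,5-trimethoxyphenyl in place of pyridin-3-yl on an aromatic carbon. Going by the values given here, nothing measured so far touches this part of the shared core. Among the compounds with values here, the single step that is known, from compound 1 to compound 2, changes the sulfonamide substituent and says nothing about what happens when the group on the core is exchanged. An expectation for compound 3 in this assay therefore rests on the standing of compound 1 alone, with wide bounds in both directions.

Compound 3 is thus expected to give about 9000 nM in this assay, within a range from 2500 nM to 30000 nM, which amounts to an expected step of a 1.3-fold lower number from compound 1 to compound 3 (0.12 log units; within the scatter).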

Compound 3, half-maximal inhibitory concentration: 9330 nM
For compound 3 the middle estimate is 1.0-fold (0.02 log units) below the measured one, within the range that was stated.
By their numbers in this assay, from the lowest: compounds 3, 2 and 1 (each within the scatter of the next).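

In this assay, the exchange at this position, on an aromatic carbon next to the ring nitrogen, gives a 1.3-fold lower number from compound 1 to compound 3 (0.11 log units; within the scatter). This place on the shared core, untouched by the earlier pair, thus accepts 3,4,5-trimethoxyphenyl, with 12 heavy atoms and a ring of carbon only, in place of pyridin-3-yl, with 6 heavy atoms and a ring hetero atom, without a change beyond the scatter, and this joins the exchange on the sulfonyl sulfur, a 1.2-fold lower number from compound 1 to compound 2 (0.08 log units; within the scatter), so that both changes made to compound 1 so far leave the number within the scatter. No evidence at hand bears on this result.

Open is whether an amine, a carboxylic acid or a longer chain on this same aromatic carbon would give a number beyond the scatter of compound 1, since the two aromatic rings shown here cannot speak for such groups. Also open is what 3,4,5-trimethoxyphenyl on the core and quinolin-3-yl on the sulfonyl sulfur would give together, as the compounds shown carry these two groups only apart.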